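Replacing dimethylamino with nitro in compound 3

A few compounds are considered here, and "the series" means these few. Any claim that something is new, unique, unknown or untested is made for them only; others in the source may bear on it.

Values in a functional assay (Homo sapiens) for inhibition; a lower number here means a stronger inhibitor, a higher number a weaker inhibitor
- compound 1 `COc1cc(/C=C/C(=O)c2ccccc2N(C)C)cc(OC)c1` gives 5700 nM
- compound 2 `COc1cc(/C=C/C(=O)c2cccc(F)c2)cc(OC)c1` gives 9200 nM
- compound 3 `COc1ccc(C(=O)/C=C/c2cccc(N(C)C)c2)c(OC)c1OC` gives 26000 nM

Compound 3 carries the highest number of the three, beyond the scatter from both compound 2 and compound 1, and is the weakest inhibitor of this small set. Compound 4 `COc1ccc(C(=O)/C=C/c2cccc([N+](=O)[O-])c2)c(OC)c1OC` has nitro in place of dimethylamino on an aromatic carbon, meta to a large group nitro in place of dimethylamino on an aromatic carbon and otherwise keeps the core of compound 3. Among the measured compounds shown here, no measured pair differs in one place, so this change has no direct precedent here. A moderate move toward a lower number in this assay is expected, and a result within the scatter would remain plausible. The estimated step is a 1.9-fold lower number from compound 3 to compound 4 (0.27 log units; within the scatter) in size. Compound 4 is estimated at 14000 nM (range 5000 nM to 38000 nM).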

Compound 4, half-maximal inhibitory concentration: 36000 nM
Compound 4: the middle estimate sits 2.6-fold (0.41 log units) below what was measured; the measured number falls inside the stated range.
By their numbers in this assay, from the lowest: compounds 1 and 2 (each within the scatter of the next); then compounds 3 and 4 (each within the scatter of the next).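

In this assay, among the compounds shown here, nitro in place of dimethylamino on an aromatic carbon, meta to a large group, gives a 1.4-fold higher number from compound 3 to compound 4 (0.14 log units; within the scatter) and is the only single-place comparison. At this position, the assay does not separate the two groups, so this exchange of nitrogen-bearing groups leaves the reading on the core of compound 3 unresolved. Nothing measured here bears on why the two groups read alike.

As far as these compounds go, it remains open whether a primary amine or a carboxylic acid at this carbon would read differently from both groups. The same exchange on the core of compound 1 is also untested in the compounds shown.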